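Sulfonyl aryl exchange in the indoline carboxamide series

The source may hold more compounds than are shown below. What is called first, only, known or untested is meant among the compounds shown, and "the series" means these compounds.

Compound 1 `CCN(CC)CCNC(=O)C1CN(S(=O)(=O)c2ccc(OC)c3ccccc23)c2ccccc21` and compound 2 `CN1CCC(N(C)C(=O)C2CN(S(=O)(=O)c3ccc4c(c3)OCCO4)c3ccccc32)CC1` share the indoline carboxamide core; compound 1 gives 20 nM in a functional assay on CHO cells for antagonist activity at 5-hydroxytryptamine receptor 6 (Homo sapiens), read by FLIPR (a lower number here means a stronger inhibitor, a higher number a weaker inhibitor), and compound 2 gives 50.1 nM. Among the two numbers measured so far, compound 2 stands highest, and the gap to compound 1 lies beyond the scatter of repeated measurements. The two compounds differ at more than one place, so nothing ties that gap to a single change.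

Compound 3 `COc1ccc(S(=O)(=O)N2CC(C(=O)N(C)C3CCN(C)CC3)c3ccccc32)c(C)c1C` is the next step from compound 2: 4-methoxy-2,3-dimethylphenyl in place of 2,3-dihydro-1,4-benzodioxin-6-yl on a sulfonyl sulfur. Among the measured compounds shown here, no pair of measured compounds isolates this change, so there is no precedent for its size. Both compound 1 and compound 3 carry a methoxy-bearing aryl on the sulfonyl sulfur, whereas compound 2 does not; beyond that the series holds nothing to guide the direction.

The expectation for compound 3 is therefore a small step, a 1.6-fold lower number from compound 2 to compound 3 (0.19 log units; within the scatter), toward a lower number but hardly beyond the scatter. Compound 3 is estimated at 32 nM, within a range from 10 nM to 100 nM.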

Compound 3, inhibition constant: 100 nM
Estimate against measurement, compound 3: 3.1-fold (0.49 log units) below; the range from low to high includes it.
By their numbers in this assay, from the lowest: compound 1; then compounds 2 and 3 (each within the scatter of the next).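

In this assay, among the compounds shown here, 4-methoxy-2,3-dimethylphenyl in place of 2,3-dihydro-1,4-benzodioxin-6-yl on a sulfonyl sulfur gives a 2.0-fold higher number from compound 2 to compound 3 (0.30 log units; within the scatter), the first step that can be read at a single place. Both groups have 10 heavy atoms, but the entering group has no six-membered non-aromatic ring and 1 hydrogen-bond acceptor rather than 2, so at this place, with the rest of the molecule held as in compound 2, this exchange of groups does not move the number beyond the scatter. No measured property of either group bears on this step, and the data offer no explanation for its size.

As far as these compounds go, whether a plain phenyl or a pyridyl group on the same sulfonyl sulfur would also stay within the scatter of compound 2 remains open, as does the separate contribution of the methoxy and the two methyl groups of the entering aryl. Compound 1, at 20 nM, differs from compound 2 and compound 3 in more than one place, so the roles of its sulfonyl aryl and its amide side chain remain unseparated.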